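Swapping oxan-4-yl for 2-chlorophenyl on a carbonyl carbon

The source may report more compounds than this note shows. Statements on the series, on what has been measured and on what is new or still open speak of the compounds shown alone.

Compound 1 `COc1ccc(-c2cnc(NC(=O)c3ccccc3C#N)n2C)cc1` and compound 2 `COc1ccc(-c2cnc(NC(=O)C3CCOCC3)n2C)cc1` share a core and differ only in the group on a carbonyl carbon. In a toxicity assay on THP-1 cells (Homo sapiens) for inhibition (a lower number here means that less compound is tolerated, a higher number that more compound is tolerated), compound 1 gives > 100000 nM, which is a limit of the assay. Compound 2 gives > 100000 nM, which is also a limit and not a number. For the measured compounds named here, the one measured step is a step that the two limits leave unreadable from compound 1 to compound 2. All that the measurements offer is the limit of > 100000 nM in this assay, at which 2 of the 2 values shown sit.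

Compound 3 `COc1ccc(-c2cnc(NC(=O)c3ccccc3Cl)n2C)cc1` keeps the same core, and the change is 2-chlorophenyl in place of oxan-4-yl on a carbonyl carbon. The entering 2-chlorophenyl, like the 2-cyanophenyl of compound 1, is a substituted phenyl group on that carbonyl carbon. The expectation leans on compound 1, whose > 100000 nM is a limit. With no readable step to scale from, no change beyond the scatter is expected in this assay, and compound 3 will most likely be reported as a limit too. The expected step is a number no higher from compound 2 to compound 3 (the limit leaves the size open), which is an estimate only. For compound 3 the estimated value is 100000 nM, with an expected range from 40000 nM to 200000 nM.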

Compound 3, half-maximal cytotoxic concentration: > 50000 nM
Compound 3 gave a limit, no number; the forecaster's own chance of this, stated with the estimate: 85%; the middle value lies beyond the limit too.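

In this assay compound 3 gives > 50000 nM, which is a limit of the assay and not a number. Compound 1 and compound 2 also stand at limits, so the steps linking the three compounds cannot be read. The compounds shown leave open whether the group on the carbonyl carbon changes the half-maximal cytotoxic concentration in this assay at all.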